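Hexyl in place of the hydroxylated branch on compound 2

This account rests on a few compounds, and the source may have more. Where it says the series, first, only, none or still open, it means among the compounds named here.

Compound 2 `CC(C)(O)Cn1nc(-c2cc(C3CC3)on2)c2c(N)ncnc21` was examined in an assay on BaF3 cells for inhibition of proto-oncogene tyrosine-protein kinase receptor Ret (Homo sapiens), read by MTT assay, with a stated time of 48 h (on this read-out lower numbers stand for stronger inhibition of growth and higher numbers for weaker inhibition of growth), where compound 2 gives 1770 nM. Among the measured compounds shown here, of the two compounds measured, compound 2 stands at the higher number; its sole neighbour is compound 1 `Nc1ncnc2c1c(-c1cc(C3CC3)on1)nn2C1CCCCC1`, which in this assay gives 520 nM. For the measured compounds named here, the single measured step, a 3.4-fold higher number from compound 1 to compound 2 (0.53 log units; beyond the scatter), placed 2-hydroxy-2-methylpropyl in place of cyclohexyl on an aromatic nitrogen and raised the number by a modest amount.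

Compound 3 `CCCCCCCn1nc(-c2cc(C3CC3)on2)c2c(N)ncnc21` has not yet been measured. It differs from compound 2 as follows: hexyl in place of 1-hydroxy-1-methylethyl on a saturated chain carbon bound to an aromatic nitrogen. Going by the values given here, the one step that bears on this change is a 3.4-fold higher number from compound 1 to compound 2 (0.53 log units; beyond the scatter), which ran in the opposite sense: a cyclohexyl gave way to a group carrying one hydrogen-bond donor and one hydrogen-bond acceptor, and the number rose. Here that donor and acceptor leave and a hexyl enters. A step of comparable size in the reverse direction is therefore expected, towards a lower number in this assay. The estimated value for compound 3 is 700 nM, with a range from 250 nM to 2000 nM. The expected step is a 2.5-fold lower number from compound 2 to compound 3 (0.40 log units; beyond the scatter).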

Compound 3, concentration for 50% growth inhibition: > 10000 nM
Compound 3: no number, only a limit (the forecaster's own chance of this, stated with the estimate: 5%); middle value at least 14-fold (1.15 log units) away from the limit.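

In this assay compound 3 gives a limit and not a number: the limit of > 10000 nM in this assay, at which 1 of the 3 values shown sits.

Replacing the hydroxylated branch with hexyl gave an at least 5.6-fold higher number from compound 2 to compound 3 (0.75 log units; beyond the scatter), so at this place on the saturated chain carbon, removing the hydrogen-bond donor and acceptor did not by itself bring the number down; the change instead moved it in the same direction as the earlier step away from cyclohexyl. Heptyl in place of cyclohexyl gave an at least 19-fold higher number from compound 1 to compound 3 (1.28 log units; beyond the scatter), which shows that two groups made of carbon alone, one a ring and the other an open chain, can lie far apart on this read-out.

The compounds shown leave open how much of this gap follows chain length and how much follows the absence of a ring, a question that a shorter chain such as propyl or butyl, or a ring such as cyclopentyl, would address. They also leave open whether a long chain can be tolerated when it ends in a hydroxyl, an amine or a carboxylic acid.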